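The source may hold more compounds than are shown below. What is called first, only, known or untested is meant among the compounds shown, and "the series" means these compounds.

In a functional assay on A549 cells (Homo sapiens) for cytotoxicity, read by MTT assay, with a stated time of 4 days (a higher number here means a weaker inhibitor, a lower number a stronger inhibitor), compound 2 `CCC(=O)Nc1ccc(C[C@H]2C(=O)OC[C@@H]2Cc2ccc(OC)c(OC)c2)cc1OC` gives > 50000 nM, which is a limit of the assay and not a number. Compound 1 `COc1cc(C[C@H]2C(=O)OC[C@@H]2Cc2ccc(OC)c(OC)c2)ccc1NC(=O)c1ccccc1` gives > 50000 nM, which is likewise a limit. The whole of the measured evidence is therefore (the limit of > 50000 nM in this assay, at which 2 of the 2 values shown sit), and no numerical potency is available as an anchor. Compound 3 `COc1cc(C[C@H]2C(=O)OC[C@@H]2Cc2ccc(OC)c(OC)c2)ccc1Nc1ccccc1` differs from compound 2 by phenyl in place of propanoyl on a nitrogen on an aromatic ring, with phenyl in place of propanoyl on a nitrogen on an aromatic ring. For the measured compounds named here, the only measured step that bears on this is a step that the two limits leave unreadable from compound 1 to compound 2, in which ethyl replaced phenyl on a carbonyl carbon, so it offers no size to carry over. A small shift towards stronger inhibition is expected, with the result most likely staying near the limit. The expected change is an at least 1.4-fold lower number from compound 2 to compound 3 (0.15 log units; that floor lies within the scatter). Compound 3 is estimated at 35000 nM, with an expected range of 10000 nM to 100000 nM.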

Compound 3, half-maximal inhibitory concentration: > 50000 nM
Compound 3 was reported as a limit; the forecaster's own chance of this, stated with the estimate: 60%; middle value at least 1.4-fold (0.15 log units) from the limit.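

Compound 3 gives a limit of the assay and not a number in this assay, as do compound 1 and compound 2, so no step among these compounds can be read: the limit of > 50000 nM in this assay, at which 3 of the 3 values shown sit.

The compounds shown leave open whether the group on this nitrogen affects the read-out at all.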